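The compounds below may be only part of what the source reports. "The series", "measured", "known", "first", "only" and "open" are said of these compounds alone.

In a functional assay on Caco-2 cells (Homo sapiens) for antiproliferative activity, with a stated time of 48 h (a lower number here means a stronger inhibitor, a higher number a weaker inhibitor), compound 2 (`CCOC(=O)c1ccc(-c2ccc(N(C)C)nn2)cc1`) gives > 25000 nM as a limit, not a number. Compound 1 (`CCOC(=O)c1cccc(-c2ccc(N(CC)CC)nn2)c1`) gives > 25000 nM as a limit too. Compound 3 (`COC(=O)c1ccc(-c2ccc(N(C)C)nn2)cc1`) gives > 25000 nM as a limit too. Among the compounds with values here, the series so far therefore shows only this (the limit of > 25000 nM in this assay, at which 3 of the 3 values shown sit) and no readable number. Within the data shown here, the one measured step (a step that the two limits leave unreadable from compound 2 to compound 3) has no readable size and concerns another part of the molecule. Compound 4 (`CCOC(=O)c1ccc(-c2ccc(OC(C)C)nn2)cc1`) differs from compound 2 by isopropoxy in place of dimethylamino on an aromatic carbon on the shared core. Among the measured compounds shown here, with no sized step to draw on, the expected step (a number no higher from compound 2 to compound 4 (the limit leaves the size open)) is none beyond the scatter, in no firm direction. Compound 4 is estimated at 25000 nM with an expected range from 8000 nM to 50000 nM for now.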

Compound 4, half-maximal inhibitory concentration: > 25000 nM
Compound 4 gave a limit, no number; the forecaster's own chance of this, stated with the estimate: 65%; the middle value lies on the limit itself.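

Compound 2 and compound 4 both give limits, not numbers, so no step can be read between them: the limit of > 25000 nM in this assay, at which 4 of the 4 values shown sit. The compounds shown leave open what size, if any, the step from dimethylamino to isopropoxy has.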